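The source may report more compounds than this note shows. Statements on the series, on what has been measured and on what is new or still open speak of the compounds shown alone.

The series shares one core and is compared in a functional assay on HCT-116 cells (Homo sapiens) for cytotoxicity, read by MTT assay, with a stated time of 72 h; on this read-out lower numbers stand for stronger inhibition and higher numbers for weaker inhibition. Compound 1 `Cc1cc(S(=O)(=O)/N=C(\N)n2nccc2-c2ccccc2)c(SCc2cccc(Cl)c2)cc1Cl` gives 7000 nM in this assay. Compound 2 `Cc1cc(S(=O)(=O)/N=C(\N)n2nccc2-c2ccccc2)c(SCc2cccc(C(F)(F)F)c2)cc1Cl` differs from compound 1 by trifluoromethyl in place of chloro on an aromatic carbon; in this assay compound 2 gives 14000 nM, and the step is a 2.0-fold higher number from compound 1 to compound 2 (0.30 log units; within the scatter). Compound 3 `Cc1cc(S(=O)(=O)/N=C(\N)n2nccc2-c2ccccc2)c(SCc2ccccc2Cl)cc1Cl` has the same atoms as compound 1, joined differently, the difference being (2-chlorophenyl in place of 3-chlorophenyl on a saturated chain carbon bound to a sulfur); in this assay compound 3 gives 18000 nM, and the step is a 2.6-fold higher number from compound 1 to compound 3 (0.41 log units; beyond the scatter). Between compound 2 and compound 3 the step is a 1.3-fold higher number from compound 2 to compound 3 (0.11 log units; within the scatter). Compound 3 is thus separated beyond the scatter only from compound 1, while its number and that of compound 2 lie within the scatter of each other.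

Compound 4 `Cc1cc(S(=O)(=O)/N=C(\N)n2nccc2-c2ccccc2)c(SCc2ccccc2C(F)(F)F)cc1Cl` has not yet been measured in this assay. It differs from compound 3 by trifluoromethyl in place of chloro on an aromatic carbon. Among the measured compounds shown here, this is the same kind of change as the one from compound 1 to compound 2, not the same: there the place was meta to a large group, whereas here it is ortho to a large group. For the measured compounds named here, compound 4 is expected to show a step of a 1.7-fold higher number from compound 3 to compound 4 (0.22 log units; within the scatter) in this assay because a 2.0-fold higher number from compound 1 to compound 2 (0.30 log units; within the scatter) is the only measured instance of this kind of change. The number for compound 4 in this assay is estimated at 30000 nM, with an expected range from 12000 nM to 75000 nM.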

Compound 4, half-maximal inhibitory concentration: 16000 nM
For compound 4 the middle estimate is 1.9-fold (0.27 log units) above the measured one; measured number inside the range.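

In this assay, the exchange of chloro for trifluoromethyl on an aromatic carbon can now be read on two cores, and the two steps do not separate: the same change on two cores in this assay, a 2.0-fold higher number (0.30 log units; within the scatter) from compound 1 to compound 2 and a 1.1-fold lower number (0.05 log units; within the scatter) from compound 3 to compound 4, 2.3-fold (0.35 log units) apart, within the scatter of two such steps

The new step is a 1.1-fold lower number from compound 3 to compound 4 (0.05 log units; within the scatter), and the shift of the trifluoromethyl group gives a 1.1-fold higher number from compound 2 to compound 4 (0.06 log units; within the scatter), so these values lie within the scatter of each other, while the step from the 3-chlorophenyl compound stands apart at a 2.3-fold higher number from compound 1 to compound 4 (0.36 log units; beyond the scatter). These two pairs do not show that the exchange has any real effect on either core, since each step lies within the scatter, and they show neither that its size carries over from one core to another nor that it depends on the place of the group.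

The compounds shown leave open how a nitrile, a methoxy group or an amine would read in place of chloro on the 2-chlorobenzyl group. They also leave open what a longer chain would do in place of the saturated chain carbon bound to the sulfur, and whether any such change would bring a number clearly apart from those seen here.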